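Cytotoxicity notes on an aryl-substituted nucleoside series

A few compounds are considered here, and "the series" means these few. Any claim that something is new, unique, unknown or untested is made for them only; others in the source may bear on it.

Measured so far in a functional assay on HCT-15 cells (Homo sapiens) for cytotoxicity, read by sulforhodamine B assay, tested at 10 uM; a higher number here means more inhibition at the concentration tested (going by the name of the read-out), a lower number less inhibition:
compound 1 `CC(=O)OC[C@H]1O[C@@H](n2cc(-c3cn(Cc4ccccc4)nn3)c(=O)[nH]c2=O)C[C@@H]1OC(C)=O` gives 92.3%
compound 2 `CCCCc1ccc(-c2cc(-c3cn([C@H]4C[C@H](OC(C)=O)[C@@H](COC(C)=O)O4)c(=O)[nH]c3=O)on2)cc1` gives 71.4%
compound 3 `CCCCCCCCc1cc(-c2cn([C@H]3C[C@H](O)[C@@H](CO)O3)c(=O)[nH]c2=O)on1` gives 88.2%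

Compound 2 holds the lowest of the three numbers in this assay. The nearest is compound 3, whose value is higher by a margin beyond the scatter; the furthest is compound 1, higher still, again beyond the scatter. Within the data shown here, no two measured compounds differ in only one place, so no single step has been measured.

Compound 4 `CCc1ccc(-c2cc(-c3cn([C@H]4C[C@H](OC(C)=O)[C@@H](COC(C)=O)O4)c(=O)[nH]c3=O)on2)cc1` is not yet measured. It departs from compound 2 by one change: hydrogen in place of ethyl on a saturated chain carbon, two bonds along the chain from an aromatic carbon

Three compounds with three different cores and sugars give no guide to what trimming butyl to ethyl does. The step from compound 2 to compound 4 in this assay is therefore expected to be small, most likely within the scatter, with a slight lean toward less inhibition as the more cautious call: a number 6.4 percentage points lower from compound 2 to compound 4 (within the scatter) is the expected step. Among the measured compounds shown here, compound 4 is estimated at 65% in this assay, in a range from 40% to 85%; the width reflects that no measured pair in this set shows the size of such a chain change.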

Compound 4, a percentage reported as inhibition, at one concentration (the size of the read-out at that concentration, not a potency): 92.2%
Beside the measured number, compound 4's estimate is 27.2 percentage points below it; measured number above the stated range.
By their numbers in this assay, from the lowest: compound 2; then compounds 3, 4 and 1 (each within the scatter of the next).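

In this assay, among these compounds, the cut from 4-butylphenyl to 4-ethylphenyl gives a number 20.8 percentage points higher from compound 2 to compound 4 (beyond the scatter) and is the first single change measured, so this saturated chain carbon, two bonds along the chain from an aromatic carbon, is a place where a change can move the read-out. The direction favours the shorter chain: with the core and acetylated sugar held constant, butyl does not bring more inhibition than ethyl, although this rests on one pair alone. Nothing available gives a reason for the step.

Only these two chain lengths can be compared on this core and sugar, so a hexyl chain, a methyl group or an unsubstituted phenyl could fall anywhere relative to this pair, and no trend with chain length can be drawn. Also open, going by these compounds, are how an amine or a carboxylic acid on the same chain carbon would behave, and whether the step would hold with the free hydroxyl groups on the sugar seen in compound 3.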